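Phenyl in place of benzyl on compound 1

A few compounds are considered here, and "the series" means these few. Any claim that something is new, unique, unknown or untested is made for them only; others in the source may bear on it.

Measured so far:
compound 1 `O=C(CCCCc1ccccc1)CC(=O)N[C@H]1CCOC1=O` - > 100000 nM (a limit)
compound 2 `O=C(CCCCCCCCCCCc1ccccc1)CC(=O)N[C@H]1CCOC1=O` - 33000 nM

In a functional assay on NCI-H630 cells (Homo sapiens) for cytotoxicity, read by sulforhodamine B assay, with a stated time of 5 days (on this read-out lower numbers stand for stronger inhibition and higher numbers for weaker inhibition), compound 1 gives only a limit and no number (> 100000 nM). Compound 1 therefore stands at the limit of > 100000 nM in this assay, at which 1 of the 2 values shown sits, in this small series. Compound 2 gives a measured number (33000 nM).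

The next compound is compound 3 `O=C(CCCc1ccccc1)CC(=O)N[C@H]1CCOC1=O`, which differs from compound 1 in one place: phenyl in place of benzyl on a saturated chain carbon, three bonds along the chain from a carbonyl carbon. For the measured compounds named here, no measured pair shows this change, so the expectation in this assay rests on compound 1 (> 100000 nM). No step beyond the scatter is expected, in either direction, and another report of only a limit is the likely outcome. The estimate amounts to a step that the limit leaves unreadable from compound 1 to compound 3 (expected, not measured). Compound 3 is estimated at 120000 nM (expected range 60000 nM to 250000 nM).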

Compound 3, half-maximal inhibitory concentration: > 100000 nM
Compound 3: a limit, no number; the forecaster's own chance of this, stated with the estimate: 80%; the middle value does not contradict the limit.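

Compound 1 and compound 3 each give only a limit, so no step can be read for phenyl in place of benzyl: the limit of > 100000 nM in this assay, at which 2 of the 3 values shown sit.

The compounds shown leave open whether phenyl in place of benzyl on this saturated chain carbon has any effect, and in which direction.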